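The compounds below may be only part of what the source reports. "The series", "measured", "known", "first", "only" and "open" are said of these compounds alone.

Measured so far in an ADME assay on MIA PaCa-2 cells (Homo sapiens) for cytotoxicity, read by MTT assay, with a stated time of 72 h; a lower number here means a stronger inhibitor, a higher number a weaker inhibitor:
- compound 1 `COc1ccc(C2=C(c3cc(OC)c(OC)c(OC)c3)C(=O)C(OC(C)=O)C2)cc1F` — 39.5 ug/mL
- compound 2 `COC(=O)c1cc(C2=C(c3cc(OC)c(OC)c(OC)c3)C(=O)CC2O[SiH2]C(C)(C)C)ccc1OC` — only a limit, > 100 ug/mL
- compound 3 `COc1ccc(C2=C(c3cc(OC)c(OC)c(OC)c3)C(=O)CC2C)cc1C(=O)O` — only a limit, > 100 ug/mL

Compound 2 sits at the limit of > 100 ug/mL in this assay, at which 2 of the 3 values shown sit, so its position among the numbers shown is known only as a limit, not as a value. Compound 4 `COc1ccc(OC)c(C2=C(c3cc(OC)c(OC)c(OC)c3)C(=O)CC2O[SiH2]C(C)(C)C)c1` differs from compound 2 by 2,5-dimethoxyphenyl in place of 4-methoxy-3-(methoxycarbonyl)phenyl on a double-bonded ring carbon. Within the data shown here, no step between measured compounds is available for this kind of change, so the expectation rests on compound 2 alone. In this assay the step from compound 2 to compound 4 is expected to be small, with no clear direction beyond the scatter, and a limit again is a real possibility. For compound 4 the expected value in this assay is 80 ug/mL, within 30 ug/mL to 200 ug/mL, so that an at least 1.2-fold lower number from compound 2 to compound 4 (0.09 log units; that floor lies within the scatter) is the estimated step.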

Compound 4, half-maximal inhibitory concentration: > 100 ug/mL
Compound 4: no number, only a limit; the forecaster's own chance of this, stated with the estimate: 45%; middle value at least 1.2-fold (0.09 log units) from the limit.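

No step can be read from compound 2 to compound 4 in this assay, since both stand only as limits: the limit of > 100 ug/mL in this assay, at which 3 of the 4 values shown sit.

The compounds shown leave open whether 2,5-dimethoxyphenyl or 4-methoxy-3-(methoxycarbonyl)phenyl gives the lower number.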